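A few compounds are considered here, and "the series" means these few. Any claim that something is new, unique, unknown or untested is made for them only; others in the source may bear on it.

Working notes on the series in an ADME assay (liver, Mus musculus) for metabolic stability, using microsomes; on this read-out higher numbers stand for a longer-lived compound and lower numbers for a shorter-lived compound. Compound 1 `CCc1nc2cc(Cl)ccn2c1C(=O)NCc1ccc(-c2ccc(C)cc2)cc1` gives 0.385 h. Compound 2 `CCc1nc2cc(Cl)ccn2c1C(=O)NCc1ccc(-c2ccc(C(=O)O)cc2)cc1` reads > 2 h, which is a limit of the assay and not a number. Compound 3 `CCc1nc2cc(Cl)ccn2c1C(=O)NCc1ccc(N2CCCCC2)cc1` gives 0.0383 h, the lowest of the three. The nearest gap is a 10-fold lower number from compound 1 to compound 3 (1.00 log units; beyond the scatter), and the gap from the limit is an at least 52-fold lower number from compound 2 to compound 3 (1.71 log units; beyond the scatter).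

Next is compound 4 `CCc1nc2cc(Cl)ccn2c1C(=O)NCc1ccc(N2CCN(C(C)C)CC2)cc1`, with the change 4-isopropylpiperazin-1-yl in place of piperidin-1-yl on an aromatic carbon. Among the measured compounds shown here, no measured step swaps one non-aromatic ring for another. The measured steps at this place, together with an at least 5.1-fold higher number from compound 1 to compound 2 (0.71 log units; beyond the scatter), show only that this assay can move well beyond the scatter there, and they give no direction for this change. Compound 4 keeps a six-membered non-aromatic ring where compound 3 gives 0.0383 h, so its number is expected to stay close to that value. The expected step is a 1.3-fold higher number from compound 3 to compound 4 (0.12 log units; within the scatter), not beyond the scatter. For compound 4 the estimated half-life is 0.05 h, with an expected range of 0.015 h to 0.17 h.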

Compound 4, half-life: 0.148 h
The estimate for compound 4 lay 3.0-fold (0.47 log units) below the measured number; measured number inside the range.
By their numbers in this assay, from the lowest: compound 3; then compound 4; then compound 1. At a limit, above all of these: compound 2.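

In this assay the swap of one six-membered non-aromatic ring for another at this place gives a 3.9-fold higher number from compound 3 to compound 4 (0.59 log units; beyond the scatter) and so moves the read-out beyond the scatter, which shows that this position responds to a change within the non-aromatic ring and not only to an exchange of ring type. Compound 4 still does not match the 4-methylphenyl group of compound 1, with a 2.6-fold lower number from compound 1 to compound 4 (0.42 log units; beyond the scatter) on the same read-out. Read only as a bound, an at least 13-fold lower number from compound 2 to compound 4 (1.13 log units; beyond the scatter) rests on a limit and not a number: the limit of > 2 h in this assay, at which 1 of the 4 values shown sits.

The compounds shown bring in the second ring nitrogen and the isopropyl group together, and they do not separate the two. From the compounds shown here alone, a piperazine with a free secondary amine or a morpholine ring at this place remains open.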